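Pyrimidinyl for methoxy on the amide nitrogen of compound 2

A few compounds are considered here, and "the series" means these few. Any claim that something is new, unique, unknown or untested is made for them only; others in the source may bear on it.

Of the compounds shown here, three sharing an aryloxyacetamide scaffold have been tested in an assay on HEK293 cells for agonist activity at transient receptor potential cation channel subfamily M member 8 (Homo sapiens), read by fluorescence and calcium flux, with a stated time of 15 min; on this read-out higher numbers stand for an effect only at larger amounts of compound and lower numbers for an effect already at smaller amounts. Compound 1 `CCCc1ccc(OCC(=O)N(CC)Cc2cccs2)cc1` gives 1810 nM in this assay. Compound 3 `CCN(Cc1cc[nH]c1)C(=O)COc1ccc(C)cc1` gives 21800 nM. Compound 2 `CON(Cc1cccs1)C(=O)COc1ccc(C)cc1` gives 10 nM, the lowest of the three numbers; its gap to compound 1 and its larger gap to compound 3 both lie beyond the scatter, so compound 2 is the most potent of the set. No two of the measured compounds differ in a single place, so no single change can be tied to a measured step.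

Compound 4 `Cc1ccc(OCC(=O)N(Cc2cccs2)c2ncccn2)cc1` has not yet been measured. Against compound 2 the change is pyrimidin-2-yl in place of methoxy on an amide-type nitrogen.

Because compound 2 gives 10 nM while its neighbours with other substituents on the amide-type nitrogen sit far higher, the change is expected to raise the number, by a moderate to large step. Compound 4 is expected to give 300 nM in this assay, within a range from 30 nM to 5000 nM. The expected step is a 30-fold higher number from compound 2 to compound 4 (1.48 log units; beyond the scatter).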

Compound 4, half-maximal effective concentration: 3700 nM
Estimate against measurement, compound 4: 12-fold (1.09 log units) below; low and high end bracket the measured number.
By their numbers in this assay, from the lowest: compound 2; then compound 1; then compound 4; then compound 3.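

Within the data shown here, the exchange of methoxy for pyrimidin-2-yl is the first change in the set made at a single place, and in this assay it gives a 370-fold higher number from compound 2 to compound 4 (2.57 log units; beyond the scatter) with the rest of compound 2 kept. The group on this amide-type nitrogen can therefore move the number by a large step on its own, and the low number of compound 2 does not carry over to this aromatic ring. No measured property of either group accounts for the step.

The compounds shown leave open whether the step follows from the loss of methoxy or from the arrival of pyrimidin-2-yl. An ethoxy, a hydroxy or a phenyl on the same nitrogen, on the same core, would help to separate the two.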